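Methoxy Replaces Hydrogen on a Dibromo Amide

The compounds below may be only part of what the source reports. "The series", "measured", "known", "first", "only" and "open" are said of these compounds alone.

Compound 2 `O=C(Nc1cccc(Cl)c1)c1cc(Br)cc(Br)c1` sits at the upper limit of an assay for inhibition of HSP60/HSP10 (Homo sapiens), with a stated time of 60 min; on this read-out higher numbers stand for weaker inhibition and lower numbers for stronger inhibition; its result, > 100000 nM, is a limit and not a number. Compound 1 `O=C(Nc1cccc(Cl)c1)c1cc(Br)cc(Br)c1O` carries a hydroxy on the same ring carbon and gives 29000 nM in this assay, so the step of an at least 3.4-fold higher number from compound 1 to compound 2 (0.53 log units; beyond the scatter) was at least modest. Compound 3 `COc1c(Br)cc(Br)cc1C(=O)Nc1cccc(Cl)c1` differs from compound 2 by methoxy in place of hydrogen on an aromatic carbon. Within the data shown here, the one measured step runs the other way, from hydroxy to hydrogen, and no step toward methoxy exists, so only a small change is expected, an at least 1.2-fold lower number from compound 2 to compound 3 (0.09 log units; that floor lies within the scatter). Compound 3 is therefore estimated at 80000 nM, between 25000 nM and 300000 nM.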

Compound 3, half-maximal inhibitory concentration: > 100000 nM
Compound 3 gave a limit, no number (the forecaster's own chance of this, stated with the estimate: 50%); middle value at least 1.2-fold (0.09 log units) away from the limit.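

In this assay, methyl in place of hydrogen on the oxygen brings an at least 3.4-fold higher number from compound 1 to compound 3 (0.53 log units; beyond the scatter) and so keeping an oxygen on this ring carbon does not keep a measurable number; among these compounds, only the free hydroxy gives one. Compound 3 stands at a limit: > 100000 nM. The step from hydrogen to methoxy cannot be read, because both compounds end at the same limit: the limit of > 100000 nM in this assay, at which 2 of the 3 values shown sit.

From the compounds shown here alone, how far compound 3 really lies from compound 1 stays open. So does whether an amine or a carboxylic acid on this ring carbon would give a number at all.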